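A few compounds are considered here, and "the series" means these few. Any claim that something is new, unique, unknown or untested is made for them only; others in the source may bear on it.

Compound 1 `COc1nc(C)c(Nc2nc(Cl)cn([C@H](CO)C3CC3)c2=O)cc1C` gives 88 nM in an assay on frontal cortex for displacement of a labelled ligand from corticotropin-releasing factor receptor 1 (Rattus norvegicus), with a stated time of 2 h; on this read-out higher numbers stand for weaker inhibition and lower numbers for stronger inhibition.
Compound 2 `COc1nc(C)c(Nc2nc(Cl)cn([C@H](COC(=O)c3ccccn3)C3CC3)c2=O)cc1C` gives 67 nM in this assay.
Compound 3 `COc1nc(C)c(Nc2nc(Cl)cn([C@H](COC(=O)Nc3ccc(Cl)cc3Cl)C3CC3)c2=O)cc1C` gives 1.7 nM in this assay.

Of the three measured compounds, compound 3 has the lowest number, and its gap to both others lies beyond the scatter. The step of a 52-fold lower number from compound 1 to compound 3 (1.71 log units; beyond the scatter) and the step of a 39-fold lower number from compound 2 to compound 3 (1.60 log units; beyond the scatter) show that the (2,4-dichlorophenyl)carbamoyl group on an oxygen on a saturated carbon brought a large gain, whereas a 1.3-fold lower number from compound 1 to compound 2 (0.12 log units; within the scatter) shows nothing beyond the scatter. Compound 4 `COc1nc(C)c(Nc2nc(Cl)cn([C@H](COC(=O)Nc3cc(Cl)cc(Cl)c3)C3CC3)c2=O)cc1C` keeps this group but with the two chlorine atoms placed differently on the ring: 3,5-dichlorophenyl in place of 2,4-dichlorophenyl on an amide-type nitrogen. Among the measured compounds shown here, no measured step speaks to such a change of chlorine placement; the two large steps only show that the dichlorophenyl carbamate as a whole matters. The expectation is therefore a modest step toward a higher number, with wide uncertainty, estimated as a 2.9-fold higher number from compound 3 to compound 4 (0.47 log units; beyond the scatter). Compound 4 is expected to give about 5 nM, within a range of 1.2 nM to 25 nM.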

Compound 4, half-maximal inhibitory concentration: 1.7 nM
Estimate against measurement, compound 4: 2.9-fold (0.47 log units) above; measured number inside the range.
By their numbers in this assay, from the lowest: compounds 3 and 4 (each within the scatter of the next); then compounds 2 and 1 (each within the scatter of the next).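

Changing 2,4-dichlorophenyl to 3,5-dichlorophenyl on the amide-type nitrogen gives no change at the digits printed from compound 3 to compound 4 (within the scatter) in this assay, so these two chlorine placements cannot be told apart at this position. The large gain from the carbamate also holds with the new placement, with a 52-fold lower number from compound 1 to compound 4 (1.71 log units; beyond the scatter) and a 39-fold lower number from compound 2 to compound 4 (1.60 log units; beyond the scatter), which shows that it does not depend on the 2,4-dichlorophenyl group alone. No evidence is available to explain why the two placements read alike.

Going by these compounds, it remains open whether both chlorine atoms matter, as a plain phenyl or a 4-chlorophenyl group on this nitrogen would show in this assay. On these data alone, it is also open whether groups other than chlorine, such as methoxy or trifluoromethyl, would fit on this ring.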